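Amide-type nitrogen substituents and paw edema inhibition

The compounds below may be only part of what the source reports. "The series", "measured", "known", "first", "only" and "open" are said of these compounds alone.

Measured so far:
compound 1 `CNC(=O)c1nc(-c2cc(OC)c(OC)c(OC)c2)n(-c2ccc(OC)cc2)n1`: 56%
compound 2 `COc1ccc(NC(=O)c2nc(-c3cc(OC)c(OC)c(OC)c3)n(-c3ccc(OC)cc3)n2)cc1`: 39%
compound 3 `COc1ccc(-n2nc(C(=O)Nc3cccc(F)c3)nc2-c2cc(OC)c(OC)c(OC)c2)cc1`: 48%

In a functional assay on the whole organism for inhibition, with Rattus norvegicus as the target, read by paw edema, with stated times of 30 min and 1 h, at a dose of 0.28 mmol/kg by the oral route (on this read-out lower numbers stand for less inhibition and higher numbers for more inhibition at the one dose given (going by the name of the read-out)), compound 3 stands second highest of three numbers; its nearest neighbour compound 1 lies a number 8 percentage points lower from compound 1 to compound 3 (within the scatter), and compound 2 lies a number 9 percentage points higher from compound 2 to compound 3 (within the scatter), both within the scatter. Compound 4 `COc1ccc(-n2nc(C(=O)Nc3ccc(C(F)(F)F)cc3)nc2-c2cc(OC)c(OC)c(OC)c2)cc1` differs from compound 3 by 4-(trifluoromethyl)phenyl in place of 3-fluorophenyl on an amide-type nitrogen.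

Bearing on this change are the aryl-for-aryl step a number 9 percentage points higher from compound 2 to compound 3 (within the scatter) and the aryl-for-methyl steps a number 17 percentage points lower from compound 1 to compound 2 (beyond the scatter) and a number 8 percentage points lower from compound 1 to compound 3 (within the scatter): one aryl exchange at this nitrogen stayed within the scatter, and only the largest step reached beyond it. An aryl-for-aryl exchange here is therefore expected to give no step beyond the scatter, a number 3 percentage points lower from compound 3 to compound 4 (within the scatter).

Compound 4 is estimated at 45%, expected between 30% and 62%.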

Compound 4, a percentage reported as inhibition, in the whole organism at one dose (the size of the read-out at that dose, not a potency): 48%
Beside the measured number, compound 4's estimate is 3 percentage points below it; low and high end bracket the measured number.
By their numbers in this assay, from the lowest: compounds 2, 3, 4 and 1 (each within the scatter of the next, the first and the last beyond it).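

In this assay the exchange of 3-fluorophenyl for 4-(trifluoromethyl)phenyl on the amide-type nitrogen gives no change at the digits printed from compound 3 to compound 4 (within the scatter) and so adds a second aryl group that cannot be told from 3-fluorophenyl. Trifluoromethyl in place of methoxy on the aromatic carbon gives a number 9 percentage points higher from compound 2 to compound 4 (within the scatter) and 4-(trifluoromethyl)phenyl in place of methyl gives a number 8 percentage points lower from compound 1 to compound 4 (within the scatter) so compound 4, like compound 3, lies within the scatter of both compound 1 and compound 2, although those two lie beyond it from each other. No measurement at hand accounts for these steps.

Open, from the compounds shown here alone, is whether a longer alkyl chain on this nitrogen would stay within the scatter of compound 1. Also open, going by these compounds, is how an aryl group carrying an amine or a carboxylic acid would read.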